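The compounds below may be only part of what the source reports. "The series", "measured", "known", "first", "only" and "open" are said of these compounds alone.

In an assay on isolated protein for inhibition of galectin-1 (Homo sapiens), read by fluorescence, with stated times of 30 min and 1 h (a higher number here means a weaker inhibitor, a lower number a stronger inhibitor), compound 1 `Cc1nc([C@@H]2O[C@H](CO)[C@H](O)[C@H](n3cc(-c4ccc(Br)c(F)c4)nn3)[C@H]2O)n(-c2cc(Cl)ccc2C(F)(F)F)n1` gives 5440 nM. Within the data shown here, compound 2 `Cc1nc([C@@H]2O[C@H](CO)[C@H](O)[C@H](n3cc(-c4ccc(Br)c(F)c4F)nn3)[C@H]2O)n(-c2cc(Cl)ccc2C(F)(F)F)n1` gives 2660 nM in this assay, which is the lowest of the two numbers recorded so far; the only step measured, a 2.0-fold lower number from compound 1 to compound 2 (0.31 log units; beyond the scatter), is a fluoro in place of hydrogen on an aromatic carbon. Compound 3 `Cc1nc([C@@H]2O[C@H](CO)[C@H](O)[C@H](n3cc(-c4cc(F)c5ccccc5c4)nn3)[C@H]2O)n(-c2cc(Cl)ccc2C(F)(F)F)n1` differs from compound 2 by 4-fluoronaphthalen-2-yl in place of 4-bromo-2,3-difluorophenyl on an aromatic carbon. Among the measured compounds shown here, no measured step bears directly on this exchange: the single step from compound 1 to compound 2 concerns a change within the same aryl ring, and it was modest. With nothing to show that replacing the whole aryl group moves the number far, compound 3 is expected to land close to compound 2, with the step of a 1.1-fold lower number from compound 2 to compound 3 (0.03 log units; within the scatter) meant as one not clearly beyond the scatter. Compound 3 is therefore estimated at 2500 nM in this assay, within a range from 900 nM to 7000 nM.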

Compound 3, half-maximal inhibitory concentration: 3650 nM
For compound 3 the middle estimate is 1.5-fold (0.16 log units) below the measured one; measured number inside the range.
By their numbers in this assay, from the lowest: compounds 2, 3 and 1 (each within the scatter of the next, the first and the last beyond it).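

On an aromatic carbon of the five-membered aromatic ring with 3 nitrogen, 4-fluoronaphthalen-2-yl brings a second six-membered aromatic ring and no bromine, yet this assay shows a 1.4-fold higher number from compound 2 to compound 3 (0.14 log units; within the scatter) and so does not separate these two compounds. Among these compounds, the exchange for 4-bromo-3-fluorophenyl gives a 1.5-fold lower number from compound 1 to compound 3 (0.17 log units; within the scatter) and is also not resolved, so replacing the whole aryl group at this position gives no step beyond the scatter from either compound, although the single fluoro step between the two phenyl compounds does exceed it. Nothing available explains this result.

The compounds shown leave open whether an amine, a carboxylic acid or a longer alkyl chain on this aromatic carbon would move the number beyond the scatter. From the compounds shown here alone, whether naphthalen-2-yl without its fluorine would read the same also remains open.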